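A few compounds are considered here, and "the series" means these few. Any claim that something is new, unique, unknown or untested is made for them only; others in the source may bear on it.

Measured in a functional assay on K562 cells (Homo sapiens), read by MTT assay, with a stated time of 72 h; a higher number here means a weaker inhibitor, a lower number a stronger inhibitor:
compound 1 `C#Cc1cn([C@@H]2O[C@H](CO)[C@@H](O)[C@H]2O)c2ncnc(SC)c12`: 30 nM
compound 2 `Cc1ncnc2c1c(-c1ccsc1)cn2[C@@H]1O[C@H](CO)[C@@H](O)[C@H]1O`: 320 nM
compound 3 `Cc1ncnc2c1c(-c1cc3ccccc3o1)cn2[C@@H]1O[C@H](CO)[C@@H](O)[C@H]1O`: 19500 nM

Compound 3 has the highest number of the three, which makes it the weakest inhibitor measured so far. Going by the values given here, only one measured step changes the group on this aromatic carbon: a 61-fold higher number from compound 2 to compound 3 (1.78 log units; beyond the scatter). In that step, 1-benzofuran-2-yl took the place of thiophen-3-yl, and the number rose sharply.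

The next structure, compound 4 `C#Cc1cn([C@@H]2O[C@H](CO)[C@@H](O)[C@H]2O)c2ncnc(C)c12`, has ethynyl in place of 1-benzofuran-2-yl on an aromatic carbon. The large group is therefore replaced by a much smaller one.

Two measurements bear on what should follow in this assay. Compound 2 shows that another group at this place can give a far lower number, with 320 nM. Compound 1 carries the same ethynyl group at this place and gives 30 nM, but it differs from compound 4 elsewhere on the core. Among the compounds with values here, no measured step isolates that second difference, so compound 1 serves only as a rough guide.

A large fall is therefore expected, well beyond the scatter, and the expected step is a 200-fold lower number from compound 3 to compound 4 (2.29 log units; beyond the scatter). For compound 4 the estimated value is 100 nM, with an expected range from 20 nM to 700 nM.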

Compound 4, half-maximal inhibitory concentration: 6920 nM
Compound 4: middle estimate off by 69-fold (1.84 log units), on the low side; the whole stated range lies below it.
By their numbers in this assay, from the lowest: compound 1; then compound 2; then compound 4; then compound 3.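

In this assay, swapping the large fused ring for ethynyl recovers very little, only a 2.8-fold lower number from compound 3 to compound 4 (0.45 log units; beyond the scatter), and the ethynyl compound still falls well short of the thiophen-3-yl compound, with a 22-fold higher number from compound 2 to compound 4 (1.33 log units; beyond the scatter). Among these three compounds, which differ only at this aromatic carbon, the number therefore does not simply fall as the group shrinks: ethynyl, the group with no ring, lies between the two ring-bearing groups. Ethynyl also does not guarantee a low number, since with it held constant, methyl in place of methylsulfanyl on an aromatic carbon gives a 230-fold higher number from compound 1 to compound 4 (2.36 log units; beyond the scatter), so that other place on the core has a large effect of its own in this series, and nothing given here explains these differences.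

As far as these compounds go, it remains open whether thiophen-3-yl combined with methylsulfanyl on the shared core would give a lower number than either change alone. Also open, from the compounds shown here alone, is how the number would respond at the ethynyl position to an amine, a phenyl ring or a longer chain such as propyl.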